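From trifluoromethyl to trifluoromethoxy at the molecule's end

The source may hold more compounds than are shown below. What is called first, only, known or untested is meant among the compounds shown, and "the series" means these compounds.

compound 1 `COc1ccc(-c2ccc(-c3ccc(-c4nc5cc(C)ccc5[nH]4)cc3)cc2)cc1OC` gives 3510 nM
compound 2 `Oc1cccc2[nH]c(-c3ccc(-c4ccc(-c5ccc(OC(F)(F)F)cc5)cc4)cc3)nc12` gives 8410 nM
compound 3 `Cc1ccc2[nH]c(-c3ccc(-c4ccc(-c5ccc(C(F)(F)F)cc5)cc4)cc3)nc2c1` gives 33200 nM
compound 4 `Cc1ccc2[nH]c(-c3ccc(-c4ccc(-c5ccc(OC(F)(F)F)cc5)cc4)cc3)nc2c1` has not yet been measured

In a functional assay on SiHa cells (Homo sapiens) for inhibition, read by sulforhodamine B assay (on this read-out lower numbers stand for stronger inhibition of growth and higher numbers for weaker inhibition of growth), compound 3 gives 33200 nM as the highest of the three numbers, so it inhibits growth least among them. Compound 4 differs from it in one place: trifluoromethoxy in place of trifluoromethyl on an aromatic carbon. Put simply, trifluoromethoxy takes the place of trifluoromethyl on an aromatic carbon, para to a large group.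

Within the data shown here, no measured step makes exactly this swap. Among the measured compounds shown here, the only measured step, a 9.5-fold higher number from compound 1 to compound 3 (0.98 log units; beyond the scatter), replaces a different group at that end of the molecule and shows that a change there can move the number beyond the scatter. Compound 2 carries the same 4-(trifluoromethoxy)phenyl end on a different core and gives 8410 nM as a lower number than compound 3 shows. The data cannot separate how much of that gap comes from the core and how much from the end group. A modest fall in this assay is therefore expected, smaller than the whole gap. The expected step is a 2.1-fold lower number from compound 3 to compound 4 (0.32 log units; beyond the scatter) in size. For compound 4 the estimated value is 16000 nM, with an expected range from 6000 nM to 40000 nM.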

Compound 4, concentration for 50% growth inhibition: 28300 nM
Compound 4: middle estimate off by 1.8-fold (0.25 log units), on the low side; measured number inside the range.
By their numbers in this assay, from the lowest: compound 1; then compound 2; then compounds 4 and 3 (each within the scatter of the next).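

In this assay the swap of trifluoromethyl for trifluoromethoxy is a 1.2-fold lower number from compound 3 to compound 4 (0.07 log units; within the scatter) and so cannot be told apart from repeat-measurement noise: on this core, the two end groups give numbers that count as the same. The end group still matters, since replacing 3,4-dimethoxyphenyl with 4-(trifluoromethoxy)phenyl gives an 8.1-fold higher number from compound 1 to compound 4 (0.91 log units; beyond the scatter) and this sits alongside a 9.5-fold higher number from compound 1 to compound 3 (0.98 log units; beyond the scatter) as a second step beyond the scatter, so both fluorine-bearing ends differ from the dimethoxy end, while they do not differ from each other. With the end group held constant, the other side of the molecule also counts: 5-methyl-1H-benzimidazol-2-yl in place of 4-hydroxy-1H-benzimidazol-2-yl gives a 3.4-fold higher number from compound 2 to compound 4 (0.53 log units; beyond the scatter) and shows that the change of core alone moves the number beyond the scatter.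

Still open, on these data alone, is whether an amine or a carboxylic acid at this end of the molecule would move the number, and whether trifluoromethoxy and trifluoromethyl would also match on the core of compound 2. Nothing available here gives a reason for any of these steps.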